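Trifluoromethoxy for trifluoromethyl on compound 3

The compounds below may be only part of what the source reports. "The series", "measured", "known", "first", "only" and "open" are said of these compounds alone.

Measured in a physicochemical assay for lipophilicity, read by HPLC, with a stated time of 90 min, tested at 100 uM (a lower number here means a more polar compound, a higher number a more lipophilic compound), so far:
- compound 1 `O=C(Nc1ccc(OC(F)(F)F)cc1)NC1CCN(C(=O)C2CCOCC2)CC1` gives 3.26
- compound 2 `O=C(Nc1ccc(OC(F)(F)F)cc1)NC1CCN(C(=O)C2CCOC2)CC1` gives 3.22
- compound 3 `O=C(Nc1ccc(C(F)(F)F)cc1)NC1CCN(C(=O)c2cc[nH]c2)CC1` gives 3.26

Compound 3 stands level with compound 1, and all three values lie within the scatter of each other. Compound 4 `O=C(Nc1ccc(OC(F)(F)F)cc1)NC1CCN(C(=O)c2cc[nH]c2)CC1` has trifluoromethoxy in place of trifluoromethyl on an aromatic carbon, para to a large group (trifluoromethoxy in place of trifluoromethyl on an aromatic carbon). Going by the values given here, the only measured step, a number 0.04 log units lower from compound 1 to compound 2 (within the scatter), concerns a different group and bears on this change only loosely. Among the compounds with values here, no measured pair makes this exchange alone, since compound 1 also differs from compound 3 elsewhere. A small upward step, a number 0.19 log units higher from compound 3 to compound 4 (within the scatter), is expected in this assay and may not clear the scatter. Compound 4 is estimated at 3.45, with an expected range from 3.2 to 3.75 overall.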

Compound 4, partition coefficient: 3.34
Estimate against measurement, compound 4: 0.11 log units above, and the stated range covers the measured number.
By their numbers in this assay, from the lowest: compounds 2, 1, 3 and 4 (each within the scatter of the next).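

In this assay, going by these compounds alone, a number 0.08 log units higher from compound 3 to compound 4 (within the scatter) comes with trifluoromethoxy in place of trifluoromethyl on an aromatic carbon, the first direct reading of this exchange para to a large group. With trifluoromethoxy held, a number 0.12 log units higher from compound 2 to compound 4 (within the scatter) comes with 1H-pyrrol-3-yl in place of oxolan-3-yl, and a number 0.08 log units higher from compound 1 to compound 4 (within the scatter) comes with 1H-pyrrol-3-yl in place of oxan-4-yl, so the three carbonyl substituents are not separated in this assay. Nothing available explains these steps.

As far as these compounds go, whether a group such as an amine or a carboxylic acid at this aromatic carbon would move the number beyond the scatter remains open. So does whether the trifluoromethoxy exchange reads the same with oxan-4-yl on the carbonyl carbon.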